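A Chlorophenylethynyl Arm in Place of the Thioether Link

This account rests on a few compounds, and the source may have more. Where it says the series, first, only, none or still open, it means among the compounds named here.

Three hydroxamic acids sharing one core have been measured in an assay on isolated protein for inhibition of matrix metalloproteinase-9 (Homo sapiens); on this read-out lower numbers stand for stronger inhibition and higher numbers for weaker inhibition. Compound 1 `Cc1ccc(Oc2ccc(N(C[C@H](O)C(=O)NO)S(=O)(=O)C(C)C)cc2)cc1` gives 286 nM in this assay. Compound 2 `Cc1ccc(Oc2ccc(N(C[C@H](O)C(=O)NO)S(=O)(=O)N(C)C)cc2)cc1` gives 243 nM. The step of a 1.2-fold lower number from compound 1 to compound 2 (0.07 log units; within the scatter) shows that this exchange on the sulfonyl sulfur hardly moves the number. Compound 3 `Cc1ccc(Sc2ccc(N(C[C@H](O)C(=O)NO)S(C)(=O)=O)cc2)cc1` gives 54 nM in this assay, the lowest of the three numbers; the nearest of the others is compound 2 and the furthest is compound 1, and both gaps lie beyond the scatter.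

Compound 4 `CS(=O)(=O)N(C[C@H](O)C(=O)NO)c1ccc(C#Cc2ccc(Cl)cc2)cc1` has not yet been measured. It differs from compound 3 in one place: 2-(4-chlorophenyl)ethynyl in place of (4-methylphenyl)sulfanyl on an aromatic carbon. Among the compounds with values here, none of the measured steps touches this part of the molecule. Within the data shown here, the only single-point step, a 1.2-fold lower number from compound 1 to compound 2 (0.07 log units; within the scatter), concerns the sulfonyl group, and compounds 1 and 2 differ from compound 3 in two places at once, so the contribution of the aryl link cannot be separated from that of the sulfonyl substituent. The expectation therefore rests on compound 3 alone and carries a wide range. Compound 4 is expected to give 80 nM in this assay, between 20 nM and 400 nM. The expected step of a 1.5-fold higher number from compound 3 to compound 4 (0.17 log units; within the scatter) is of a size within the scatter, with no direction claimed.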

Compound 4, half-maximal inhibitory concentration: 47 nM
Estimate against measurement, compound 4: 1.7-fold (0.23 log units) above; the range from low to high includes it.
By their numbers in this assay, from the lowest: compounds 4 and 3 (each within the scatter of the next); then compounds 2 and 1 (each within the scatter of the next).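

In this assay, the exchange of (4-methylphenyl)sulfanyl for 2-(4-chlorophenyl)ethynyl on an aromatic carbon, para to a large group, gives a 1.1-fold lower number from compound 3 to compound 4 (0.06 log units; within the scatter). Within the data shown here, this is the first single-place reading at this position, since the only earlier step concerned the sulfonyl sulfur, and it shows that an arm with a triple bond outside aromatic rings and a chlorine on its ring reads the same in this assay as an arm with a sulfur link and a methyl on its ring, with the difference staying inside the scatter. Nothing available bears on why the two arms give values so close together.

The compounds shown leave open whether the triple bond and the chlorine each matter on their own, as no arm here pairs the triple bond with a methyl or the sulfur link with a chlorine. Also open, as far as these compounds go, is how this position responds to a different kind of group, such as a carboxylic acid or an amine on the far ring, and whether the isopropyl or dimethylamino group on the sulfonyl sulfur would read the same alongside the 2-(4-chlorophenyl)ethynyl arm.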